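The source may hold more compounds than are shown below. What is called first, only, known or untested is meant among the compounds shown, and "the series" means these compounds.

Working notes on the series. In a functional assay on the whole organism (Pleural cavity) for inhibition, with Rattus norvegicus as the target, at a dose of 25 mg/kg (on this read-out higher numbers stand for more inhibition at the one dose given (going by the name of the read-out) and lower numbers for less inhibition), compound 1 `CCC1(C)C(=O)N(c2ccccc2)c2ncccc21` gives 12%, and compound 2 `CC1(F)C(=O)N(c2ccccc2)c2ncccc21` gives 35%. Within the data shown here, compound 2 stands highest of the two numbers measured so far in this assay; its nearest neighbour is compound 1, and the change from compound 1 to compound 2 was a number 23 percentage points higher from compound 1 to compound 2 (beyond the scatter), for fluoro in place of ethyl on a saturated ring carbon.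

Compound 3 `CC1C(=O)N(c2ccccc2)c2ncccc21` has not yet been measured. It differs from compound 2 in one place: hydrogen in place of fluoro on a saturated ring carbon. Among the measured compounds shown here, no measured step bears directly on the exchange of fluoro for hydrogen; the only step in hand removed ethyl and introduced fluoro, a modest rise beyond the scatter. Whether the fluoro itself carries that rise cannot be read from these two compounds alone. The expectation for compound 3 is therefore a step of a number 10 percentage points lower from compound 2 to compound 3 (within the scatter), within the scatter or a little below it. Compound 3 is estimated at 25%, in the range 5% to 45%.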

Compound 3, a percentage reported as inhibition, in the whole organism at one dose (the size of the read-out at that dose, not a potency): 18%
The estimate for compound 3 lay 7 percentage points above the measured number; measured number inside the range.
By their numbers in this assay, from the lowest: compounds 1 and 3 (each within the scatter of the next); then compound 2.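

In this assay the fluoro group now has a direct comparison on this saturated ring carbon: hydrogen in its place gives a number 17 percentage points lower from compound 2 to compound 3 (beyond the scatter) and so takes away most of the earlier rise. Hydrogen in place of ethyl gives a number 6 percentage points higher from compound 1 to compound 3 (within the scatter) and does not separate the two compounds, so among these three only compound 2, the one bearing fluoro, stands apart from the others. Nothing at hand offers an explanation for this difference at the position.

The compounds shown leave open whether chloro, a hydroxyl group or an amine on this saturated ring carbon would stand with compound 2 or with compound 3. Also open, from the compounds shown here alone, is whether the gap between fluoro and hydrogen would hold at other doses.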